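Adding a Chloro Group Where Three Analogues Reach the Limit

This account rests on a few compounds, and the source may have more. Where it says the series, first, only, none or still open, it means among the compounds named here.

Three compounds sharing one core were tested in a functional assay on DU-145 cells (Homo sapiens) for cytotoxicity, read by MTT assay; a higher number here means a weaker inhibitor, a lower number a stronger inhibitor. Compound 1 has the structure `CC(O)(CS(=O)(=O)c1ccccc1)c1nc(-c2ccccc2)no1`. In this assay compound 1 gives > 100000 nM, which is a limit of the assay rather than a number. Compound 2, `CC(O)(CS(=O)(=O)c1ccccc1)c1nc(-c2ccc(Cl)cc2)no1`, differs from compound 1 by chloro in place of hydrogen on an aromatic carbon. Compound 2 gives > 100000 nM, again a limit. Compound 3, `CC(O)(CS(=O)(=O)c1ccc(F)cc1)c1nc(-c2ccccc2)no1`, differs from compound 1 by fluoro in place of hydrogen on an aromatic carbon, and this is also how the core of compound 3 differs from the core of compound 1. Compound 3 gives > 100000 nM, once more a limit. The step that the two limits leave unreadable from compound 1 to compound 2 and the step that the two limits leave unreadable from compound 1 to compound 3 cannot be sized because of the limit of > 100000 nM in this assay, at which 3 of the 3 values shown sit. Compound 4, `CC(O)(CS(=O)(=O)c1ccc(F)cc1)c1nc(-c2ccc(Cl)cc2)no1`, not yet measured, differs from compound 3 by chloro in place of hydrogen on an aromatic carbon, the same change as from compound 1 to compound 2, at the same place. That expectation for compound 4 rests on compound 2 giving > 100000 nM, a limit. The step that the limit leaves unreadable from compound 3 to compound 4 is what is expected. Compound 4 is expected to give about 200000 nM, most likely again only a limit.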

Compound 4, half-maximal inhibitory concentration: > 100000 nM
Compound 4: only a limit was reported; the forecaster's own chance of this, stated with the estimate: 85%; the middle value is on the limit's open side.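

Among these compounds, no step can be sized from compound 3 to compound 4 or from compound 2 to compound 4, because the values give no numbers to compare: the limit of > 100000 nM in this assay, at which 4 of the 4 values shown sit. The compounds shown leave open how far each of the four lies past that limit, and so whether chloro or fluoro in place of hydrogen makes any difference.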